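Guanidine series: single fluorine removed from compound 3

The source may report more compounds than this note shows. Statements on the series, on what has been measured and on what is new or still open speak of the compounds shown alone.

Measured compounds:
compound 1, `Cc1[nH]cnc1CSCC(=O)NC(=N)NCCCc1c[nH]cn1`, 101%
compound 2, `N=C(NCCCc1c[nH]cn1)NC(=O)CC(c1ccccc1)c1ccccc1`, 85%
compound 3, `N=C(NCCCc1c[nH]cn1)NC(=O)CC(c1ccc(F)cc1)c1ccc(F)cc1`, 76%

All three were tested in a functional assay on cardiac atrium for agonist activity at histamine H2 receptor (Cavia porcellus); a higher number here means a larger maximal response, a lower number a smaller maximal response. Compound 1 gives 101%, the highest of the three numbers. Compound 3 stands lowest of the three: its nearest neighbour is compound 2, whose number is higher by an amount that lies within the scatter of repeated measurements, while the gap up to compound 1 is beyond the scatter. Within the data shown here, no two measured compounds differ in only one place, so no single-point step is available within the measured set.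

Compound 4, `N=C(NCCCc1c[nH]cn1)NC(=O)CC(c1ccccc1)c1ccc(F)cc1`, is not yet measured. It differs from compound 3 in one place: hydrogen in place of fluoro on an aromatic carbon. Among the measured compounds shown here, no measured pair isolates this change, so what can be said rests on the numbers of compound 2, which carries no fluorine, and compound 3, which carries two. Those two numbers sit within the scatter of each other, and compound 4 lies between them in structure. Accordingly the step is expected to be small, a number 4 percentage points higher from compound 3 to compound 4 (within the scatter), upward if anything but not beyond the scatter. For compound 4 in this assay the estimated largest response is 80%, in the range 66% to 94%.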

Compound 4, largest response reached (Emax), in percent of the reference or control that the assay uses: 95%
The estimate for compound 4 lay 15 percentage points below the measured number, outside the stated range (above it).
By their numbers in this assay, from the lowest: compounds 3, 2, 4 and 1 (each within the scatter of the next, the first and the last beyond it).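

In this assay, taking one fluoro off the doubly fluorinated compound gives a number 19 percentage points higher from compound 3 to compound 4 (beyond the scatter), so the 4-fluorophenyl to phenyl change now has its own measured step, and it lies beyond the scatter. Placing a single fluoro on the unsubstituted diphenyl compound gives a number 10 percentage points higher from compound 2 to compound 4 (within the scatter), so among these compounds the first fluoro cannot be told apart from hydrogen, whereas the second goes with a smaller maximal response. The data at hand offer no explanation for this difference between the first and second fluoro.

From the compounds shown here alone, whether the drop is specific to fluoro remains open, since chloro, methyl or methoxy at the same place could behave differently. Going by these compounds, it is also open whether the maximal response alone shifts here, as these compounds give no potency values.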